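The source may report more compounds than this note shows. Statements on the series, on what has been measured and on what is new or still open speak of the compounds shown alone.

Measured so far:
compound 1, `CCCCCCCCCO[C@@H]1[C@@H](N)[C@@H](OCC(O)CNCCCO)O[C@H](CN)[C@H]1OCCCCCCCCC`: 89.9%
compound 2, `NC[C@H]1O[C@H](O[C@H]2[C@H](O)[C@@H](OCc3ccc4ccccc4c3)[C@H](N)C[C@@H]2N)[C@H](N)[C@@H](OCc2ccc3ccccc3c2)[C@@H]1O`: 86%

In a toxicity assay on the whole organism (J774 cells) for cytotoxicity, with Mus musculus as the target, read by MTT assay, with a stated time of 24 h, tested at 10 uM (on this read-out higher numbers stand for a weaker effect at the one concentration tested and lower numbers for a stronger effect), compound 1 gives 89.9%, and compound 2 gives 86%; the two numbers lie within the scatter of each other, so nothing separates them. Compound 3, `CCCCCCCCCO[C@@H]1[C@@H](N)[C@@H](OC[C@H](O)CN)O[C@H](CN)[C@H]1OCCCCCCCCC`, has not yet been measured. It differs from compound 1 in one place: 2-amino-1-hydroxyethyl in place of 1-hydroxy-2-((3-hydroxypropyl)amino)ethyl on a saturated chain carbon bound to an oxygen on a saturated carbon. Going by the values given here, no step between measured compounds exists to guide the size of this change. The step of a number 5.9 percentage points lower from compound 1 to compound 3 (within the scatter) is expected to be small, at most around the scatter, in the direction of a slightly stronger effect. Compound 3 is thus expected to give 84%, within 68% to 98%.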

Compound 3, a percentage reported as activity, at one concentration (the size of the read-out at that concentration, not a potency): 88%
Compound 3: the middle estimate sits 4 percentage points below what was measured; low and high end bracket the measured number.
By their numbers in this assay, from the lowest: compounds 2, 3 and 1 (each within the scatter of the next).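

In this assay, 2-amino-1-hydroxyethyl in place of 1-hydroxy-2-((3-hydroxypropyl)amino)ethyl gives a number 1.9 percentage points lower from compound 1 to compound 3 (within the scatter). Going by these compounds alone, this is the first reading at this position, and it shows that going from the group of 8 heavy atoms to the group of 4 does not separate the two compounds at the one concentration tested.

As far as these compounds go, it remains open whether a carboxylic acid or a guanidine in place of 2-amino-1-hydroxyethyl would move the number in this assay beyond the scatter. No measurement at hand offers an explanation for this result.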